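The compounds below may be only part of what the source reports. "The series", "measured", "known", "first", "only" and "open" are said of these compounds alone.

In a functional assay on HepG2 cells (Homo sapiens) for cytotoxicity, read by MTT assay, with a stated time of 48 h (a lower number here means a stronger inhibitor, a higher number a weaker inhibitor), compound 1 (`CC1=NN(C(=O)c2ccccc2)C(c2cccc(C)c2O)C1`) gives 177000 nM. Compound 2 (`CC1=NN(S(=O)(=O)c2ccccc2)C(c2ccccc2O)C1`) gives 57200 nM, the lower of the two numbers, with the gap to compound 1 beyond the scatter. Compound 3 (`CC1=NN(S(=O)(=O)c2ccc(C)cc2)C(c2ccccc2O)C1`) differs from compound 2 in one place: methyl in place of hydrogen on an aromatic carbon. Among the measured compounds shown here, no measured pair shows this change, so a small shift toward a lower number, or none beyond the scatter, is expected in this assay. The expected change is a 1.1-fold lower number from compound 2 to compound 3 (0.06 log units; within the scatter). For compound 3 the estimated value is 50000 nM, with an expected range of 22000 nM to 120000 nM.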

Compound 3, half-maximal inhibitory concentration: 66800 nM
For compound 3 the middle estimate is 1.3-fold (0.13 log units) below the measured one, and the stated range covers the measured number.
By their numbers in this assay, from the lowest: compounds 2 and 3 (each within the scatter of the next); then compound 1.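

In this assay, among the compounds shown here, the change from phenyl to 4-methylphenyl gives a 1.2-fold higher number from compound 2 to compound 3 (0.07 log units; within the scatter), the first one-place comparison. At this position, para to a large group, a methyl therefore produces no change beyond the scatter. This single step says nothing about larger or differently built groups at the same place.

As far as these compounds go, whether an amine, a carboxylic acid or a longer chain at this position would move the number beyond the scatter remains open. No measurement at hand accounts for this step.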